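Three thioether sulfonylguanidines and a fourth to be tested

The source may report more compounds than this note shows. Statements on the series, on what has been measured and on what is new or still open speak of the compounds shown alone.

Measured so far in a functional assay on HeLa cells (Homo sapiens) for cytotoxicity, read by MTT assay, with a stated time of 72 h; a lower number here means a stronger inhibitor, a higher number a weaker inhibitor:
Compound 1, `Cc1cc(S(=O)(=O)/N=C(\N)n2nccc2-c2ccccc2)c(SCc2ccc(C(F)(F)F)cc2)cc1Cl`, gives 17000 nM.
Compound 2, `Cc1cc(S(=O)(=O)/N=C(\N)n2nccc2-c2ccccc2)c(SCc2ccccc2Cl)cc1Cl`, gives 19000 nM.
Compound 3, `Cc1cc(S(=O)(=O)/N=C(\N)n2nccc2-c2ccccc2)c(SCc2ccccc2C(F)(F)F)cc1Cl`, gives 20000 nM.

All three share one core and differ only in the group on the saturated chain carbon bound to a sulfur. The steps between them are small: a 1.1-fold higher number from compound 1 to compound 2 (0.05 log units; within the scatter), a 1.2-fold higher number from compound 1 to compound 3 (0.07 log units; within the scatter) and a 1.1-fold higher number from compound 2 to compound 3 (0.02 log units; within the scatter), each within the scatter. Compound 3 therefore stands together with compound 1 and compound 2; nothing in this assay separates the three.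

Compound 4, `Cc1cc(S(=O)(=O)/N=C(\N)n2nccc2-c2ccccc2)c(SCc2ccc(Cl)cc2)cc1Cl`, is not yet measured. It differs from compound 3 in one place: 4-chlorophenyl in place of 2-(trifluoromethyl)phenyl on a saturated chain carbon bound to a sulfur. The measured steps that bear on it are those that move a substituent around the same phenyl ring or exchange chloro for trifluoromethyl, and none of them left the scatter. The exchange that produces compound 4 is of the same kind, so no step beyond the scatter is expected in this assay, in either direction.

The estimate for compound 4 is accordingly 18500 nM, with a range from 9000 nM to 38000 nM, which is expected to mean a 1.1-fold lower number from compound 3 to compound 4 (0.03 log units; within the scatter).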

Compound 4, half-maximal inhibitory concentration: 3000 nM
Compound 4: the middle estimate sits 6.2-fold (0.79 log units) above what was measured; the whole stated range lies above it.
By their numbers in this assay, from the lowest: compound 4; then compounds 1, 2 and 3 (each within the scatter of the next).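

Only the 4-chlorophenyl group on the saturated chain carbon bound to a sulfur moves the number in this assay beyond the scatter, and it does so against each of the other three groups (a 6.7-fold lower number from compound 3 to compound 4 (0.82 log units; beyond the scatter)) (a 6.3-fold lower number from compound 2 to compound 4 (0.80 log units; beyond the scatter)) (a 5.7-fold lower number from compound 1 to compound 4 (0.75 log units; beyond the scatter)), which makes compound 4 the strongest inhibitor of the four. The placing of the group on the phenyl ring therefore matters for chloro, as the step from compound 2 shows, whereas the two trifluoromethyl compounds gave no such separation (a 1.2-fold higher number from compound 1 to compound 3 (0.07 log units; within the scatter)). The exchange between chloro and trifluoromethyl also proves not to be a single step of fixed size, and its outcome depends on the ring that carries it: the same change on two cores in this assay, a 1.1-fold higher number (0.02 log units; within the scatter) from compound 2 to compound 3 and a 5.7-fold higher number (0.75 log units; beyond the scatter) from compound 4 to compound 1, 5.4-fold (0.73 log units) apart, beyond the scatter of two such steps.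

The compounds shown leave open whether the lower number belongs to chloro itself or would also come with a 4-bromophenyl, 4-methylphenyl or 4-methoxyphenyl group on the same carbon, and where an unsubstituted phenyl group would stand. Going by these compounds, it also remains open whether the 4-chlorophenyl group keeps this advantage when a longer chain joins it to the sulfur.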